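From fluoro to acetamido at the assay limit

The source may report more compounds than this note shows. Statements on the series, on what has been measured and on what is new or still open speak of the compounds shown alone.

In a functional assay (plasma) for inhibition, with Oryctolagus cuniculus as the target (a lower number here means that less compound is needed, a higher number that more compound is needed for the effect), compound 1 (`CCOC(=O)c1c(C)cc2cnn(-c3ccc(F)cc3)c(=O)c2c1C`) gives >= 50 uM, which is a limit of the assay and not a number. Sharing the core of compound 1, compound 2 (`CCOC(=O)c1c(C)cc2cnn(-c3ccc(OC)c(OC)c3)c(=O)c2c1C`) gives >= 50 uM, again only a limit. The data so far therefore amount to the limit of >= 50 uM in this assay, at which 2 of the 2 values shown sit, and compound 1 offers no exact starting value.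

Compound 3 (`CCOC(=O)c1c(C)cc2cnn(-c3ccc(NC(C)=O)cc3)c(=O)c2c1C`) carries acetamido in place of fluoro on an aromatic carbon, para to a large group: acetamido in place of fluoro on an aromatic carbon. Among the measured compounds shown here, no measured step shows what a change at this place does. Because compound 2 also stands at the limit of >= 50 uM, no step beyond the scatter is expected in this assay. In numbers, the expected change is a number no higher from compound 1 to compound 3 (the limit leaves the size open). Compound 3 is estimated at 50 uM, with an expected range of 15 uM to 150 uM.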

Compound 3, concentration for half-maximal effect: >= 50 uM
Compound 3 was reported as a limit; the forecaster's own chance of this, stated with the estimate: 70%; the middle value lies on the limit itself.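

Compound 1 and compound 3 both stand at a limit of the assay and not at a number, so no step from fluoro to acetamido can be read: the limit of >= 50 uM in this assay, at which 3 of the 3 values shown sit.

The compounds shown leave open what any group at this aromatic carbon does in this assay.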